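This account rests on a few compounds, and the source may have more. Where it says the series, first, only, none or still open, it means among the compounds named here.

For the measured compounds named here, in a functional assay on HepG2 cells (Homo sapiens) for cytotoxicity, read by MTT assay, with a stated time of 48 h (on this read-out higher numbers stand for weaker inhibition and lower numbers for stronger inhibition), compound 1 (`CN(C)CCNc1ccnc2cc(OCc3ccc(F)cc3)ccc12`) gives 790 nM as the lowest of the two numbers so far. Compound 2 (`CCCCOc1ccc2c(Cl)ccnc2c1`) gives 2640 nM as the higher number, and that gap lies beyond the scatter. The two compounds differ in more than one place, so the gap is not a single-change step.

Compound 3 (`CCOc1ccc2c(NCCN(C)C)ccnc2c1`) is not yet measured. It departs from compound 1 at one place: methyl in place of 4-fluorophenyl on a saturated chain carbon bound to an oxygen on an aromatic ring ( methyl in place of 4-fluorophenyl on a saturated chain carbon bound to an oxygen on an aromatic ring). Cut one bond further out, this reads 4-fluorobenzyl to ethyl.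

Going by the values given here, no measured pair shows this change alone, so the size of the step remains a judgement. Among the compounds with values here, a rise in the number is expected in this assay since compound 2 without a 4-fluorophenyl group gives 2640 nM as the only other reading, though this comparison is loose. The expected change is a 3.2-fold higher number from compound 1 to compound 3 (0.50 log units; beyond the scatter) as estimated here. For compound 3 the estimated value is 2500 nM with an expected range of 900 nM to 7000 nM in a first measurement.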

Compound 3, half-maximal inhibitory concentration: 5680 nM
The estimate for compound 3 lay 2.3-fold (0.36 log units) below the measured number, within the range that was stated.
By their numbers in this assay, from the lowest: compound 1; then compound 2; then compound 3.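

In this assay, the series now has its first single-change step: methyl in place of 4-fluorophenyl on a saturated chain carbon bound to an oxygen on an aromatic ring gives a 7.2-fold higher number from compound 1 to compound 3 (0.86 log units; beyond the scatter), so the number at this position responds to the change. Cut one bond further out, the change reads 4-fluorobenzyl to ethyl: 7 heavy atoms, including the six-membered aromatic ring and the fluorine, leave and 1 heavy atom enters, and this single pair is the only reading of that exchange. No supporting measurement accounts for the size of the step or shows which part of the departing group carries it.

This pair cannot separate the aromatic ring from the fluorine, so a plain benzyl group and a cyclohexylmethyl group at the same place would be the informative neighbours of compound 1. Also open, from the compounds shown here alone, is whether the step keeps its size when a morpholine replaces the dimethylamino group on the shared core.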